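Fluoro on the benzothiazole of an amide series

The compounds below may be only part of what the source reports. "The series", "measured", "known", "first", "only" and "open" are said of these compounds alone.

Measured compounds:
- compound 1 `O=C(Nc1nc2ccc(F)cc2s1)c1cn(-c2ccccc2)nc1-c1ccccc1`: 3250 nM
- compound 2 `O=C(Nc1nc2ccc(F)cc2s1)c1cn(-c2ccccc2)nc1-c1ccc(Cl)cc1`: 5790 nM
- compound 3 `COc1ccc(-c2nn(-c3ccccc3)cc2C(=O)Nc2nc3ccccc3s2)cc1`: 6670 nM

In a functional assay on PC-3 cells (Homo sapiens) for cytotoxicity, read by MTT assay, with a stated time of 72 h (on this read-out lower numbers stand for stronger inhibition and higher numbers for weaker inhibition), compound 3 gives the highest of the three numbers, with 6670 nM. Compound 2 sits nearest to it, within the scatter, and compound 1 furthest, a gap that lies beyond the scatter. Among the compounds with values here, the only step between measured compounds that differ in one place, a 1.8-fold higher number from compound 1 to compound 2 (0.25 log units; within the scatter), concerns a change on the other aromatic ring of the shared core and is itself within the scatter.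

Compound 4 `COc1ccc(-c2nn(-c3ccccc3)cc2C(=O)Nc2nc3ccc(F)cc3s2)cc1` differs from compound 3 by fluoro in place of hydrogen on an aromatic carbon. Within the data shown here, no measured pair isolates this change: compounds 1 and 2 both carry the fluoro, compound 3 does not, and each also differs from compound 3 elsewhere. With nothing that bears on the step directly, compound 4 is expected to stay within the scatter of compound 3 in this assay, a step of a 1.1-fold lower number from compound 3 to compound 4 (0.05 log units; within the scatter). The estimate for compound 4 is 6000 nM, in a range from 2500 nM to 14000 nM.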

Compound 4, half-maximal inhibitory concentration: 4930 nM
Beside the measured number, compound 4's estimate is 1.2-fold (0.09 log units) above it; the range from low to high includes it.
By their numbers in this assay, from the lowest: compounds 1, 4, 2 and 3 (each within the scatter of the next, the first and the last beyond it).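

In this assay, the change from 1,3-benzothiazol-2-yl to 6-fluoro-1,3-benzothiazol-2-yl can now be read on its own, and it stays within the scatter (a 1.4-fold lower number from compound 3 to compound 4 (0.13 log units; within the scatter)), so this position accepts fluoro in place of hydrogen without a change the assay can resolve in the methoxy compounds. With the fluoro held constant, methoxy can also be set against chloro (a 1.2-fold lower number from compound 2 to compound 4 (0.07 log units; within the scatter)) and against hydrogen (a 1.5-fold higher number from compound 1 to compound 4 (0.18 log units; within the scatter)), and neither step leaves the scatter, so these three groups are not told apart at that place on the core. Nothing available explains these results or links them to any property of the groups.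

On these data alone, whether fluoro gives a similarly small step in compounds carrying chloro or hydrogen instead of methoxy remains open. So does the outcome with an amine or a carboxylic acid at the fluoro position, or with a longer chain such as ethoxy in place of methoxy.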